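Adding a Methyl to a Polymethoxy Core: Expected Lipophilicity

This account rests on a few compounds, and the source may have more. Where it says the series, first, only, none or still open, it means among the compounds named here.

Compound 1 `COc1c(OC)c(OC(=O)C(C)C)c2ccccc2c1OC(=O)C(C)C` is measured in a physicochemical assay for lipophilicity (a lower number here means a more polar compound, a higher number a more lipophilic compound), where compound 1 gives 4.61. Compound 2 `COc1c(OC)c(OC(=O)C(C)C)c2c(C)cccc2c1OC(=O)C(C)C` carries one more group, (methyl in place of hydrogen on an aromatic carbon), and in this assay compound 2 gives 5. This single change made a step of a number 0.39 log units higher from compound 1 to compound 2 (beyond the scatter). Compound 3 `COc1c(OC)c(OC(C)=O)c2cc(C)ccc2c1OC(C)=O` has a different core; how the core of compound 3 differs from the core of compound 1 is not broken down here. In this assay compound 3 gives 2.86, the lowest of the three values.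

Compound 4 `COc1c(OC)c(OC(C)=O)c2cc(C)c(C)cc2c1OC(C)=O` is not yet measured. It differs from compound 3 by methyl in place of hydrogen on an aromatic carbon. This is the same kind of change as the one made earlier, though the surroundings differ: in compound 2 the entering methyl sits ortho to a fused ring and meta to a fused ring, whereas in compound 4 it sits ortho to a methyl group, meta to a fused ring and para to a fused ring. The expectation rests on the earlier step of a number 0.39 log units higher from compound 1 to compound 2 (beyond the scatter). For compound 4 a step of similar size is expected, a number 0.40 log units higher from compound 3 to compound 4 (beyond the scatter). Compound 4 is therefore estimated at 3.26, with a likely range from 2.9 to 3.6.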

Compound 4, partition coefficient: 3.14
For compound 4 the middle estimate is 0.12 log units above the measured one, within the range that was stated.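

In this assay, putting a methyl in place of a hydrogen on an aromatic carbon gives a number 0.28 log units higher from compound 3 to compound 4 (within the scatter), so compound 3 and compound 4 cannot be told apart by this measurement, whereas on the core of compound 1 the same kind of change gave a number 0.39 log units higher from compound 1 to compound 2 (beyond the scatter), a step beyond the scatter. This shows that a step seen on one core need not stand clear of the scatter on another, but it does not show that the change acts differently on the two cores, since a single pair on each core is too little to set a rule, and in compound 4 the methyl also has a different place, ortho to a methyl group. Nothing available here explains the difference between the two steps.

The compounds shown leave open how this step would look on any further core or at other places on these two cores. They also leave open how this assay would respond if an amine, a carboxylic acid or a longer chain stood where the methyl enters.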